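Chloroacetamido in place of acetamido on the sialic acid series

The compounds below may be only part of what the source reports. "The series", "measured", "known", "first", "only" and "open" are said of these compounds alone.

Measured compounds:
compound 1 `CC(=O)N[C@H]1[C@H]([C@@H](O)[C@H](O)CNC(=O)c2ccc(Cl)cc2)O[C@@](OCc2ccc(Cl)cc2)(C(=O)O)C[C@@H]1O`, 15000 nM
compound 2 `CC(=O)N[C@H]1[C@H]([C@@H](O)[C@H](O)CNC(=O)c2ccc(Cl)cc2)O[C@@](OCc2c(F)c(F)c(F)c(F)c2F)(C(=O)O)C[C@@H]1O`, 6100 nM
compound 3 `CC(=O)N[C@H]1[C@H]([C@@H](O)[C@H](O)CNC(=O)c2ccc(Cl)cc2)O[C@@](OCc2cccc(F)c2F)(C(=O)O)C[C@@H]1O`, 2400 nM

In an in vitro assay on cells for binding affinity to myelin-associated glycoprotein (Mus musculus), read by surface plasmon resonance (a higher number here means weaker binding, a lower number tighter binding), compound 3 gives the lowest number of the three, and its steps to the other two lie beyond the scatter: a 2.5-fold lower number from compound 2 to compound 3 (0.41 log units; beyond the scatter) and a 6.3-fold lower number from compound 1 to compound 3 (0.80 log units; beyond the scatter). It is thus the tightest binder measured so far. Compound 4 `O=C(CCl)N[C@H]1[C@H]([C@@H](O)[C@H](O)CNC(=O)c2ccc(Cl)cc2)O[C@@](OCc2cccc(F)c2F)(C(=O)O)C[C@@H]1O` keeps everything of compound 3 except the acetamido group: chloro in place of hydrogen on a saturated chain carbon bound to a carbonyl carbon.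

The three measured steps all concern the aryl group on the saturated chain carbon bound to an oxygen on a saturated carbon (a 2.5-fold lower number from compound 1 to compound 2 (0.39 log units; beyond the scatter), a 6.3-fold lower number from compound 1 to compound 3 (0.80 log units; beyond the scatter), a 2.5-fold lower number from compound 2 to compound 3 (0.41 log units; beyond the scatter)); none touches the carbon bound to the carbonyl carbon where compound 4 differs. Among the compounds with values here, no measured step therefore bears on this change, and its direction cannot be read from the series. In the absence of a bearing step, a step no larger than the scatter is expected, no change at the digits printed from compound 3 to compound 4 (within the scatter). For compound 4 in this assay an estimate of 2400 nM is expected, with a range from 800 nM to 7000 nM.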

Compound 4, dissociation constant: 2100 nM
The estimate for compound 4 lay 1.1-fold (0.06 log units) above the measured number; low and high end bracket the measured number.
By their numbers in this assay, from the lowest: compounds 4 and 3 (each within the scatter of the next); then compound 2; then compound 1.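

In this assay, within the data shown here, the first reading at the acetamido group is a 1.1-fold lower number from compound 3 to compound 4 (0.06 log units; within the scatter) and so lies within the scatter. All earlier steps concerned the aryl group on the other side of the core, whereas this one shows that, with the 2,3-difluorophenyl group held fixed, the saturated chain carbon bound to a carbonyl carbon takes chloro in place of hydrogen without a step beyond the scatter. Nothing available explains this result.

A single atom at one position leaves open how far this tolerance extends: bromomethyl, trifluoroacetyl, a longer chain such as propionyl, or an aminomethyl group could read differently. On these data alone, it also remains open whether the acetamido to ((chloromethyl)carbonyl)amino change reads the same with the 4-chlorophenyl or 2,3,4,5,6-pentafluorophenyl group in place.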